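A few compounds are considered here, and "the series" means these few. Any claim that something is new, unique, unknown or untested is made for them only; others in the source may bear on it.

In an ADME assay on HEK-293T cells (Homo sapiens) for cytotoxicity, read by luminescence, with a stated time of 24 h (a lower number here means that less compound is tolerated, a higher number that more compound is tolerated), compound 3 (`COc1ccc(Cn2c(C(=O)N3CCCC3)cc3sccc32)cc1`) stands at > 100000 nM as a limit of the assay and not a number. Compound 1 (`COc1ccc(Cn2c(C(=O)NCc3ccccc3)cc3sccc32)cc1`) gives > 100000 nM as a limit too. Compound 2 (`COc1ccc(Cn2c(C(=O)NC(C)c3ccccc3)cc3sccc32)cc1`) likewise gives > 100000 nM as a limit. Compound 4 (`COc1ccc(Cn2c(C(=O)N3CCNCC3)cc3sccc32)cc1`) has piperazin-1-yl in place of pyrrolidin-1-yl on a carbonyl carbon and is otherwise the same as compound 3. Among the measured compounds shown here, three measured steps bear on this: a step that the two limits leave unreadable from compound 1 to compound 3 and a step that the two limits leave unreadable from compound 2 to compound 3 and a step that the two limits leave unreadable from compound 1 to compound 2 give no size to build on. The evidence amounts to the limit of > 100000 nM in this assay, at which 3 of the 3 values shown sit, and nothing more. In this assay no step beyond the scatter is therefore expected in either direction. The expected change is a number no higher from compound 3 to compound 4 (the limit leaves the size open) in this estimate. Compound 4 is expected at 100000 nM (estimated range 30000 nM to 150000 nM).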

Compound 4, half-maximal cytotoxic concentration: > 100000 nM
Compound 4 gave a limit, no number; the forecaster's own chance of this, stated with the estimate: 80%; the middle value sits exactly at the limit.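

In this assay, among the compounds shown here, compound 4 gives > 100000 nM, which is a limit of the assay and not a number, so no step between compound 4 and compound 1, compound 2 or compound 3 can be read. The compounds shown leave open where the true cytotoxic concentration of any of the four lies, and whether the groups on the carbonyl carbon change it.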